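The source may hold more compounds than are shown below. What is called first, only, known or untested is meant among the compounds shown, and "the series" means these compounds.

Measured in an ADME assay on A-431 cells (Homo sapiens) for cytotoxicity, with a stated time of 48 h; a higher number here means a weaker inhibitor, a lower number a stronger inhibitor:
compound 1 `COc1ccc(CSc2nnc(-c3cc([N+](=O)[O-])cc([N+](=O)[O-])c3)n2Cc2ccccc2)cc1` gives > 30000 nM; this is a limit of the assay, not a number.
compound 2 `O=[N+]([O-])c1cc(-c2nnc(SCc3ccc(Cl)cc3)n2Cc2ccccc2)cc([N+](=O)[O-])c1` gives > 30000 nM; this too is a limit of the assay, not a number.

Compound 2 stands only at a limit in this assay, and the same holds for every value shown so far (the limit of > 30000 nM in this assay, at which 2 of the 2 values shown sit). Among the compounds with values here, the single measured step, a step that the two limits leave unreadable from compound 1 to compound 2, is consequently of unreadable size, and no direction of change can be read from it. Compound 3 `O=[N+]([O-])c1cc(-c2nnc(SCc3ccc(Cl)c(Cl)c3)n2Cc2ccccc2)cc([N+](=O)[O-])c1` differs from compound 2 by chloro in place of hydrogen on an aromatic carbon. Within the data shown here, no measured step bears on this particular change with a readable size, so no shift beyond the scatter can be predicted in either direction. The expectation for compound 3 in this assay is that the step that the limit leaves unreadable from compound 2 to compound 3 is estimated as none beyond the scatter. Compound 3 is estimated at 40000 nM, within a range of 15000 nM to 120000 nM, with the greater likelihood that only a limit and no number is reported.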

Compound 3, half-maximal inhibitory concentration: > 30000 nM
Compound 3 ended at the assay's limit; the forecaster's own chance of this, stated with the estimate: 80%; the middle value lies beyond the limit too.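

No step can be read among compound 1, compound 2 and compound 3 in this assay, because all three values are limits of the assay and not numbers: the limit of > 30000 nM in this assay, at which 3 of the 3 values shown sit.

The compounds shown leave open whether 4-chlorobenzyl to 3,4-dichlorobenzyl, or chloro in place of methoxy, changes the half-maximal inhibitory concentration at all.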